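Compound 3: A Permeability Estimate Without a Baseline

The source may hold more compounds than are shown below. What is called first, only, known or untested is meant among the compounds shown, and "the series" means these compounds.

Compound 1 `COC(=O)Nc1c(N)nc(-c2nn(Cc3ccccc3F)c3ncccc23)nc1N`: 79 nm/s
Compound 2 `CC(C)OC(=O)Nc1c(N)nc(-c2nn(Cc3ccccc3F)c3ncccc23)nc1N`: "not determined" (no result reported)

Both compounds went into an ADME assay on Caco-2 cells (Homo sapiens) for permeability, read by LC-MS, in the apical to basolateral direction, with a stated time of 2 h, tested at 2 uM (on this read-out lower numbers stand for lower permeability and higher numbers for higher permeability), a test of how readily a molecule crosses a layer of cultured cells. In this assay compound 1 gives 79 nm/s. Compound 2 has no single number: its entry reads "not determined" (no result reported), so there is no result from which to measure a change.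

The next molecule is compound 3 `Nc1nc(-c2nn(Cc3ccccc3F)c3ncccc23)nc(N)c1NC(=O)OC1CCC1`, which keeps the shared core. The structural change is cyclobutyl in place of isopropyl on an oxygen next to a carbonyl group. In words, this is cyclobutyl in place of isopropyl on an oxygen next to a carbonyl group, and neither group carries a net charge.

Among the measured compounds shown here, no measured pair shows what this swap does in this assay, so no direction can be favoured, and no step beyond the usual scatter is expected. For the measured compounds named here, the only number available as a guide is that of compound 1 at 79 nm/s, which leaves the expectation wide. For compound 3 the estimated value is 90 nm/s, with an expected range of 30 nm/s to 250 nm/s.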

Compound 3, apparent permeability: 23 nm/s
The estimate for compound 3 lay 3.9-fold (0.59 log units) above the measured number, outside the stated range (below it).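

Among the compounds shown here, putting cyclobutyl in place of methyl on an oxygen next to a carbonyl group gives a 3.4-fold lower number from compound 1 to compound 3 (0.54 log units; beyond the scatter) in this assay and provides the first measured step at this position. The two compounds differ only in this group, so this position can shift the read-out beyond the usual scatter, something a single value from compound 1 could not show. The step from isopropyl to cyclobutyl cannot be read with no number for compound 2, and no measurement at hand accounts for the lower value of compound 3.

From the compounds shown here alone, without a number for the isopropyl compound, it remains open whether the value falls gradually as carbon atoms are added to this group or whether the four-membered ring of compound 3 matters in its own right. Also open, going by these compounds, is where an open chain such as n-butyl, a smaller ring such as cyclopropyl, or a group carrying an amine would fall relative to compound 1 and compound 3, and only such neighbours could separate the effect of chain size from that of the ring.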